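Removing a phenyl group from two related stomach-active compounds

The source may hold more compounds than are shown below. What is called first, only, known or untested is meant among the compounds shown, and "the series" means these compounds.

Compound 1 `N=C(S)CCn1ncccc1=O`, compound 2 `N=C(S)CCn1nc(-c2ccccc2)ccc1=O` and compound 3 `N=C(S)CCn1nc(-c2ccccc2)c2ccccc2c1=O` have each been tested in a functional assay on the whole organism (stomach) with Rattus norvegicus as the target; a higher number here means that more compound is needed for the effect, a lower number that less compound is needed. Compound 1 gives > 100 mg/kg, which is a limit of this assay rather than a number. Compound 2 gives 87.3 mg/kg. Compound 3 gives 66.5 mg/kg, and these two values lie within the usual scatter of each other. The difference between the core of compound 2 and the core of compound 3 is not broken down here. From compound 2 to compound 1 the change is hydrogen in place of phenyl on an aromatic carbon, and it gave an at least 1.1-fold higher number from compound 2 to compound 1 (0.05 log units; that floor lies within the scatter); the step cannot be sized more closely than that, since compound 1 sits at the limit of > 100 mg/kg in this assay, at which 1 of the 3 values shown sits.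

Compound 4 `N=C(S)CCn1ncc2ccccc2c1=O` has not yet been measured. It differs from compound 3 by hydrogen in place of phenyl on an aromatic carbon. This is the same kind of change as that from compound 2 to compound 1, but not the same, since in compound 3 the carbon belongs to a ring that is part of a fused or bridged system of two rings, ortho to a fused ring and meta to a fused ring. Resting on an at least 1.1-fold higher number from compound 2 to compound 1 (0.05 log units; that floor lies within the scatter), the expected step is a 1.7-fold higher number from compound 3 to compound 4 (0.22 log units; within the scatter), a somewhat higher number. Compound 4 is therefore expected to give about 110 mg/kg in this assay, most likely between 55 mg/kg and 250 mg/kg.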

Compound 4, dose for half-maximal effect: 90.1 mg/kg
Compound 4: middle estimate off by 1.2-fold (0.09 log units), on the high side; low and high end bracket the measured number.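

In this assay, hydrogen in place of phenyl on the core of compound 3 gave a 1.4-fold higher number from compound 3 to compound 4 (0.13 log units; within the scatter), so on this core, losing the phenyl group produced no difference that can be told apart from the usual scatter. Set beside the same change on the core of compound 2, this result fits the idea that the change behaves alike on both cores, but it does not establish that idea: the same change on two cores in this assay, an at least 1.1-fold higher number (0.05 log units; that floor lies within the scatter) from compound 2 to compound 1 and a 1.4-fold higher number (0.13 log units; within the scatter) from compound 3 to compound 4; the limit leaves it open whether they differ. Compound 1 gives > 100 mg/kg, which is a limit of the assay and not a number.

The compounds shown carry only phenyl or hydrogen at this place, so they leave open how a methyl group, a chlorine atom or an amine would behave there, and whether any such group would shift the number beyond the scatter. They also leave open what a longer chain would do in place of the chain that all four compounds share.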